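Adding a Methyl to the Hydroxypiperidine Ring

This account rests on a few compounds, and the source may have more. Where it says the series, first, only, none or still open, it means among the compounds named here.

Two measured compounds share one core and differ only in the amine attached to it. Compound 1 `CCCN(C)c1ncnc2[nH]cc(-c3cccc(Cl)c3)c12` carries a methyl(propyl)amino group; in an assay for inhibition of serine/threonine-protein kinase 3 (Homo sapiens), read by luminescence and ADP-Glo, in the presence of a further agent that is not named here (on this read-out higher numbers stand for weaker inhibition and lower numbers for stronger inhibition), compound 1 gives 218 nM. Compound 2 `OC1CCN(c2ncnc3[nH]cc(-c4cccc(Cl)c4)c23)CC1` carries a 4-hydroxypiperidin-1-yl group instead, and in this assay compound 2 gives 127 nM. The step of a 1.7-fold lower number from compound 1 to compound 2 (0.23 log units; within the scatter) leaves both numbers within the scatter, so compound 2 holds the lower of the two numbers without standing apart from compound 1.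

Compound 3 `CC1(O)CCN(c2ncnc3[nH]cc(-c4cccc(Cl)c4)c23)CC1` takes one further step: methyl in place of hydrogen on a saturated ring carbon, turning 4-hydroxypiperidin-1-yl into 4-hydroxy-4-methylpiperidin-1-yl. Among the measured compounds shown here, the only measured step, from compound 1 to compound 2, exchanged the whole amine and does not test a methyl on the ring. With nothing closer to lean on, the expected step in this assay is a 1.0-fold higher number from compound 2 to compound 3 (0.01 log units; within the scatter), none beyond the scatter. Compound 3 is therefore estimated to give 130 nM in this assay, within a range from 50 nM to 340 nM.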

Compound 3, half-maximal inhibitory concentration: 189 nM
The estimate for compound 3 lay 1.5-fold (0.16 log units) below the measured number; the range from low to high includes it.
By their numbers in this assay, from the lowest: compounds 2, 3 and 1 (each within the scatter of the next).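

In this assay the methyl on this saturated ring carbon, three ring bonds from the ring nitrogen, gives the step of a 1.5-fold higher number from compound 2 to compound 3 (0.17 log units; within the scatter) and so makes no difference beyond the scatter, a result that the exchange of whole amines between compound 1 and compound 2 could not give. Set against the methyl(propyl)amino group, the 4-hydroxy-4-methylpiperidin-1-yl group gives the step of a 1.2-fold lower number from compound 1 to compound 3 (0.06 log units; within the scatter) and leaves all three compounds within the scatter of one another. Nothing at hand accounts for how closely these numbers agree.

The compounds shown leave open whether something larger than methyl on this ring carbon, such as an ethyl or phenyl group, would move the number beyond the scatter. They also leave open what would follow if an amine or a methoxy group took the place of the hydroxyl.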